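A few compounds are considered here, and "the series" means these few. Any claim that something is new, unique, unknown or untested is made for them only; others in the source may bear on it.

In a functional assay on the whole organism (blood, strain Wistar-Okamoto) with Rattus norvegicus as the target, with a stated time of 5 days (on this read-out higher numbers stand for an effect only at larger amounts of compound and lower numbers for an effect already at smaller amounts), compound 1 `CCC(CC)/N=C(\NC#N)Nc1cccnc1` gives 20 mg/kg, compound 2 `CCC(C)(CC)/N=C(\NC#N)Nc1cccnc1` gives 0.5 mg/kg, and compound 3 `CCC(/N=C(\NC#N)Nc1ccncc1)C(C)C` gives 5 mg/kg.

Compound 2 differs from compound 1 by methyl in place of hydrogen on a saturated chain carbon bound to a double-bonded nitrogen and two saturated chain carbons, a change that made a 40-fold lower number from compound 1 to compound 2 (1.60 log units; beyond the scatter). Compound 4 `CC(C)C(/N=C(\NC#N)Nc1ccncc1)C(C)C` has not yet been measured; it differs from compound 3 by methyl in place of hydrogen on a saturated chain carbon bound to two saturated chain carbons. This is the same kind of change, not the same one: in compound 1 the carbon gaining the methyl is bound to a double-bonded nitrogen and two saturated chain carbons, while in compound 3 it is bound to two saturated chain carbons. The difference between the two cores is not broken down here.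

In this assay, the expected step is a 2.5-fold lower number from compound 3 to compound 4 (0.40 log units; beyond the scatter), smaller than the earlier one. This rests on the earlier gain of a 40-fold lower number from compound 1 to compound 2 (1.60 log units; beyond the scatter) arising at the carbon bound to the double-bonded nitrogen, a place left unchanged in compound 4. Compound 4 is estimated at 2 mg/kg, within a range of 0.5 mg/kg to 10 mg/kg.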

Compound 4, minimum effective dose: 8 mg/kg
For compound 4 the middle estimate is 4.0-fold (0.60 log units) below the measured one; low and high end bracket the measured number.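

In this assay the added methyl gives a 1.6-fold higher number from compound 3 to compound 4 (0.20 log units; within the scatter), so on this core it brings no change that can be told apart from repeat measurements. The large gain seen on the core of compound 1 therefore does not carry over as a general rule for this change, and the two steps truly differ: the same change on two cores in this assay, a 40-fold lower number (1.60 log units; beyond the scatter) from compound 1 to compound 2 and a 1.6-fold higher number (0.20 log units; within the scatter) from compound 3 to compound 4, 64-fold (1.81 log units) apart, beyond the scatter of two such steps. What this does not show is why they differ, since the methyl enters at differently bound carbons and the cores differ as well, and these compounds cannot separate the two.

Still open, as far as these compounds go, is how a methyl on the carbon bound to the double-bonded nitrogen would behave on the core of compound 3. Also open, from the compounds shown here alone, is how a longer chain, such as propyl, or a hydroxyl group would behave on the saturated chain carbon bound to two saturated chain carbons.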